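The compounds below may be only part of what the source reports. "The series", "measured", "known", "first", "only" and "open" are said of these compounds alone.

Compounds measured so far in a functional assay on MGC-803 cells (Homo sapiens) for cytotoxicity, read by MTT assay, with a stated time of 72 h; on this read-out lower numbers stand for stronger inhibition and higher numbers for weaker inhibition:

- compound 1 `C=C1C(=O)[C@@]23C(=O)OC[C@]4(C(=O)CCC(C)(C)[C@H]4C=O)[C@@H]2CC[C@@H]1[C@H]3OC(=O)c1ccccc1` gives 1920 nM
- compound 2 `C=C1C(=O)[C@@]23C(=O)OC[C@]4(C(=O)CCC(C)(C)[C@H]4C=O)[C@@H]2CC[C@@H]1[C@H]3OC(=O)c1ccc(C)cc1` gives 2240 nM
- compound 3 `C=C1C(=O)[C@@]23C(=O)OC[C@]4(C(=O)CCC(C)(C)[C@H]4C=O)[C@@H]2CC[C@@H]1[C@H]3OC(=O)c1ccccc1F` gives 3940 nM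

Compound 3 stands clear of compound 1 but not of compound 2. The two steps that place it are a 2.1-fold higher number from compound 1 to compound 3 (0.31 log units; beyond the scatter), which is modest, and a 1.8-fold higher number from compound 2 to compound 3 (0.25 log units; within the scatter), which does not separate the pair.

The next structure is compound 4 `C=C1C(=O)[C@@]23C(=O)OC[C@]4(C(=O)CCC(C)(C)[C@H]4C=O)[C@@H]2CC[C@@H]1[C@H]3OC(=O)c1ccc(Cl)cc1`, not yet measured. The change is 4-chlorophenyl in place of 2-fluorophenyl on a carbonyl carbon, in words 4-chlorophenyl in place of 2-fluorophenyl on a carbonyl carbon.

Among the compounds with values here, no compound with a chlorine has been measured in this set, so the evidence is indirect. Within the data shown here, the closest precedent is a 1.2-fold higher number from compound 1 to compound 2 (0.07 log units; within the scatter), where a methyl on an aromatic carbon left the value within the scatter. Among the measured compounds shown here, the only step beyond the scatter is the fluoro step to compound 3, and compound 4 no longer carries that 2-fluorophenyl. Compound 4 is therefore expected to fall in the range of compound 1 and compound 2 rather than to open new ground. The expected change is a small move towards a lower number, a 1.7-fold lower number from compound 3 to compound 4 (0.23 log units; within the scatter), which would stay within the scatter. For compound 4 the estimated value is 2300 nM, with an expected range from 1100 nM to 4700 nM in this assay.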

Compound 4, half-maximal inhibitory concentration: 3120 nM
Beside the measured number, compound 4's estimate is 1.4-fold (0.13 log units) below it, within the range that was stated.
By their numbers in this assay, from the lowest: compounds 1, 2, 4 and 3 (each within the scatter of the next, the first and the last beyond it).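

In this assay, adding a chlorine to the phenyl gives a 1.6-fold higher number from compound 1 to compound 4 (0.21 log units; within the scatter), and chloro in place of methyl gives a 1.4-fold higher number from compound 2 to compound 4 (0.14 log units; within the scatter), so this chlorine does not separate compound 4 from either compound without a halogen. The exchange of 2-fluorophenyl for 4-chlorophenyl gives a 1.3-fold lower number from compound 3 to compound 4 (0.10 log units; within the scatter), so compound 4 is not separated from compound 3 either, although the ends of the series remain apart, with a 2.1-fold higher number from compound 1 to compound 3 (0.31 log units; beyond the scatter). A halogen on this phenyl therefore does not by itself produce a clear separation from compound 1 and compound 2, and the data offer no independent measurement that could explain these small differences.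

The 2-fluorophenyl and 4-chlorophenyl groups differ in both the halogen and its place on the ring, so the compounds shown cannot separate those two changes. From the compounds shown here alone, it also remains open whether a phenyl carrying an amine or a carboxylic acid, or a longer chain in place of the phenyl on the carbonyl carbon, would give a value clearly apart from this narrow band.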